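From 2-methoxyphenyl to 4-methylphenyl on a shared core

This account rests on a few compounds, and the source may have more. Where it says the series, first, only, none or still open, it means among the compounds named here.

Within the data shown here, in a functional assay on MGC-803 cells (Homo sapiens) for antiproliferative activity, read by CellTiter-Glo, with a stated time of 72 h (on this read-out lower numbers stand for stronger inhibition and higher numbers for weaker inhibition), compound 2 (`COc1ccccc1-c1cc(/C=C/c2ccc(C(=O)NO)cc2)ccn1`) gives 6350 nM, the highest number of the three compounds measured so far. Compound 1 (`O=C(NO)c1cccc(/C=C/c2ccnc(-c3cc(F)ccc3O)c2)c1`) gives 2710 nM, and compound 3 (`O=C(NO)c1ccc(/C=C/c2ccnc(-c3cccc(O)c3)c2)cc1`) gives 2100 nM.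

Compound 4 (`Cc1ccc(-c2cc(/C=C/c3ccc(C(=O)NO)cc3)ccn2)cc1`) has not yet been measured. It differs from compound 2 in one place, next to the ring nitrogen: 4-methylphenyl in place of 2-methoxyphenyl on an aromatic carbon. In short, 4-methylphenyl stands in place of 2-methoxyphenyl.

Among the measured compounds shown here, only one measured step removes that same 2-methoxyphenyl group: a 3.0-fold lower number from compound 2 to compound 3 (0.48 log units; beyond the scatter). There, 3-hydroxyphenyl is the group that enters, so this modest step is only a loose guide for a different group. Compound 1 offers no single-change comparison with compound 2.

A smaller step in the same direction therefore seems reasonable, although it may not clear the usual scatter. The expected change is a 1.8-fold lower number from compound 2 to compound 4 (0.25 log units; within the scatter). For compound 4 the estimated value in this assay is 3600 nM, with an expected range from 1400 nM to 9000 nM.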

Compound 4, half-maximal inhibitory concentration: 1910 nM
Compound 4: middle estimate off by 1.9-fold (0.28 log units), on the high side; measured number inside the range.
By their numbers in this assay, from the lowest: compounds 4, 3 and 1 (each within the scatter of the next); then compound 2.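

In this assay, swapping the group on the aromatic carbon next to the ring nitrogen gives a 3.3-fold lower number from compound 2 to compound 4 (0.52 log units; beyond the scatter), so the lower number seen earlier with 3-hydroxyphenyl does not depend on a hydroxyl group. The step between the two replacement groups is a 1.1-fold lower number from compound 3 to compound 4 (0.04 log units; within the scatter), so 4-methylphenyl and 3-hydroxyphenyl cannot be told apart at this position in this assay, although one carries oxygen and the other carbon only. No measurement here accounts for these steps.

The change from 2-methoxyphenyl to 4-methylphenyl alters both the substituent and where it sits on the ring, so the compounds shown leave open which of the two matters. Also open, as far as these compounds go, is how plain phenyl, 4-methoxyphenyl or 4-aminophenyl would read at this position.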